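Removing Two Methyl Groups From the Oxadiazole Phenyl Ring

The source may report more compounds than this note shows. Statements on the series, on what has been measured and on what is new or still open speak of the compounds shown alone.

Compound 1 `CC(C)(C)n1ncc(OCc2nnc(-c3cc(F)c(Cl)cc3Cl)s2)c(Cl)c1=O` gives 67.1 ug/mL in a functional assay on the whole organism for inhibition, with Mythimna separata as the target, with a stated time of 5 days; on this read-out higher numbers stand for an effect only at larger amounts of compound and lower numbers for an effect already at smaller amounts.
Compound 2 `Cc1cc(C)cc(-c2nnc(COc3cnn(C(C)(C)C)c(=O)c3Cl)o2)c1` reaches only the assay limit of > 300 ug/mL in this assay.
Compound 3 `CC(C)(C)n1ncc(OCc2nnc(-c3cc(F)c(Cl)c([N+](=O)[O-])c3Cl)o2)c(Cl)c1=O` likewise reaches only the assay limit of > 300 ug/mL in this assay.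

For the measured compounds named here, compound 2 therefore stands on a limit rather than on a number: of the three values shown, two sit at the limit of > 300 ug/mL in this assay, at which 2 of the 3 values shown sit, and the only numbered value belongs to compound 1, which carries a different five-membered ring and a different substituted phenyl. Going by the values given here, no two measured compounds differ in just one place, so no measured step gives a yardstick for the change considered here.

Compound 4 `CC(C)(C)n1ncc(OCc2nnc(-c3ccccc3)o2)c(Cl)c1=O` differs from compound 2 by phenyl in place of 3,5-dimethylphenyl on an aromatic carbon, in words phenyl in place of 3,5-dimethylphenyl on an aromatic carbon. Among the compounds with values here, compound 2 and compound 3, which share the same core and five-membered ring, both sit at the limit, and nothing among the measured compounds points to a gain from removing the two methyl groups. The step from compound 2 to compound 4 is expected to be a number no higher from compound 2 to compound 4 (the limit leaves the size open), that is, none beyond the scatter, with compound 4 most likely again at the limit. Compound 4 is estimated at 300 ug/mL, within a range from 100 ug/mL to 1000 ug/mL.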

Compound 4, half-maximal effective concentration: 12.2 ug/mL
Compound 4: the middle estimate sits 25-fold (1.39 log units) above what was measured; the measured number lies below the stated range.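

For the compounds shown here, this is the first comparison here in which only one place changes, and it shows that what the phenyl carries on this aromatic carbon of the five-membered ring matters a great deal in this assay: going from 3,5-dimethylphenyl to plain phenyl gives an at least 24-fold lower number from compound 2 to compound 4 (1.39 log units; beyond the scatter). Compound 2 stands at a limit of the assay, > 300 ug/mL, and not at a measured number. The step is therefore only a minimum, and the real gap could be wider, because one end of it is a limit and not a number: the limit of > 300 ug/mL in this assay, at which 2 of the 4 values shown sit.

Going by these compounds, with only these two groups compared on an otherwise unchanged molecule, it remains open whether a single methyl group on the phenyl would already cost as much as two, and how a methoxy group or an amine on that ring would behave. Going by these compounds alone, it is also open whether plain phenyl would bring a similar gain on the different five-membered ring of compound 1, since no compound here pairs that ring with plain phenyl.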